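Ring configuration change from compound 1 to compound 4

This account rests on a few compounds, and the source may have more. Where it says the series, first, only, none or still open, it means among the compounds named here.

In a functional assay on a cell-free system (plasma, Homo sapiens), with a stated time of 3 min (a higher number here means a weaker inhibitor, a lower number a stronger inhibitor), compound 1 (`CC(C)(C)[C@@H](O)C(=O)N1C[C@@H]2C[C@@H]2[C@H]1C(=O)NCc1cc(Cl)ccc1-n1cnnn1`) gives 570 nM, at the low end of the three numbers. Compound 2 (`O=C(NCc1cc(Cl)ccc1-n1cnnn1)[C@@H]1[C@H]2C[C@H]2CN1C(=O)[C@H](O)c1ccccc1`) gives 960 nM, and compound 3 (`O=C(NCc1cc(Cl)ccc1-n1cnnn1)[C@@H]1[C@H]2C[C@H]2CN1C(=O)[C@H](O)Cc1ccccc1`) gives 1200 nM. Compound 4 (`CC(C)(C)[C@@H](O)C(=O)N1C[C@H]2C[C@H]2[C@H]1C(=O)NCc1cc(Cl)ccc1-n1cnnn1`) keeps the tert-butyl group of compound 1: the two compounds have the same atoms and bonds and differ only in configuration as drawn: 2 of 4 stereo elements differ; a stereocentre at a saturated ring carbon is drawn R in compound 1 and S in compound 4; a stereocentre at a saturated ring carbon is drawn S in compound 1 and R in compound 4.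

The measured steps only exchange that group: a 1.7-fold higher number from compound 1 to compound 2 (0.23 log units; within the scatter), a 2.1-fold higher number from compound 1 to compound 3 (0.32 log units; beyond the scatter) and a 1.3-fold higher number from compound 2 to compound 3 (0.10 log units; within the scatter). Among the compounds with values here, they bear on this change only indirectly, as no measured pair differs in ring configuration. The direction is therefore a judgement, with a wide margin. The expected change is a 5.3-fold higher number from compound 1 to compound 4 (0.72 log units; beyond the scatter), towards a weaker inhibitor and beyond the scatter. The estimate for compound 4 is 3000 nM, with an expected range of 700 nM to 13000 nM.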

Compound 4, half-maximal inhibitory concentration: 1200 nM
Estimate against measurement, compound 4: 2.5-fold (0.40 log units) above; the range from low to high includes it.
By their numbers in this assay, from the lowest: compounds 1, 2, 3 and 4 (each within the scatter of the next, the first and the last beyond it).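

In this assay, inverting two ring stereocentres with the tert-butyl group held constant gives a 2.1-fold higher number from compound 1 to compound 4 (0.32 log units; beyond the scatter). Within the data shown here, the earlier steps only exchanged tert-butyl for phenyl or benzyl, so this is the first sign that ring configuration alone shifts the number, though modestly. The step can be assigned to that change alone because of one structural point: the fact that compounds 1 and 4 differ only in the configuration as drawn

From the compounds shown here alone, whether the same ring inversion shifts the number with phenyl or benzyl in place of tert-butyl remains open. So does how an amine or a carboxylic acid at that place would read under either ring configuration.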